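Furan hydrazones: methoxy to hydroxy on the difluorophenyl member

A few compounds are considered here, and "the series" means these few. Any claim that something is new, unique, unknown or untested is made for them only; others in the source may bear on it.

Measured so far:
compound 1 `O=C(N/N=C/c1ccccc1O)c1ccc(-c2ccc(F)cc2)o1` – 53.9%
compound 2 `COc1ccccc1/C=N/NC(=O)c1ccc(-c2ccc(F)cc2F)o1` – 59.5%

Both compounds were run in a functional assay on KB cells (Homo sapiens) for inhibition, read by sulforhodamine B assay, with a stated time of 48 h, tested at 10 uM; on this read-out higher numbers stand for more inhibition of growth at the one concentration tested and lower numbers for less inhibition of growth. Compound 1 gives 53.9%, and compound 2 gives 59.5%. The two numbers lie within the scatter of each other; compound 2 is the one at the upper end of the pair, but no separation can be read from that. Going by the values given here, no pair differing in one place has been measured, so no step size is known from the series itself.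

Compound 3 `O=C(N/N=C/c1ccccc1O)c1ccc(-c2ccc(F)cc2F)o1` is next. It keeps the difluorophenyl side of compound 2 and changes the other end: hydrogen in place of methyl on an oxygen on an aromatic ring. Among the compounds with values here, the only guidance is indirect: compound 1 carries the same hydroxy group and gives 53.9%, and compound 2 with the methoxy gives 59.5%, which sit within the scatter. On that basis the step in this assay is expected to stay within the scatter, with no clear direction, so the expected step from compound 2 to compound 3 is a number 2.5 percentage points lower from compound 2 to compound 3 (within the scatter). Compound 3 is therefore estimated at 57%, within the range 42% to 72%.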

Compound 3, percent growth inhibition at one concentration: 75.3%
Compound 3: middle estimate off by 18.3 percentage points, on the low side, and the stated range ends below it.
By their numbers in this assay, from the lowest: compounds 1 and 2 (each within the scatter of the next); then compound 3.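

Methoxy to hydroxy on the difluorophenyl member gives a number 15.8 percentage points higher from compound 2 to compound 3 (beyond the scatter) in this assay and so shows that the group on this oxygen can move the read-out, which the earlier pair, differing in more than one place, could not show. With the 2-hydroxyphenyl end held, fluoro in place of hydrogen on an aromatic carbon gives a number 21.4 percentage points higher from compound 1 to compound 3 (beyond the scatter) and so shows that the other end of the molecule also responds, leaving compound 3 as the most active of the three on steps beyond the scatter. Nothing at hand explains either step or shows how the two changes work together.

Going by these compounds, it remains open whether the gain from methoxy to hydroxy also holds on the monofluorophenyl member, and so whether the two steps add or depend on each other. Also open, on these data alone, is how an amine or a carboxylic acid at this place on the aromatic ring would compare with the hydroxy, and whether these differences at one concentration in one cell line carry over to full concentration-response measurements.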